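A few compounds are considered here, and "the series" means these few. Any claim that something is new, unique, unknown or untested is made for them only; others in the source may bear on it.

Measured so far:
Compound 1, `O=C1[C@@H](NS(=O)(=O)c2ccc(-c3ccon3)s2)CCN1Cc1cc2cc[nH]cc-2n1`, gives 49% in an assay on isolated protein for inhibition of coagulation factor X (Oryctolagus cuniculus), tested at 1 uM; a higher number here means more inhibition at the concentration tested (going by the name of the read-out), a lower number less inhibition.
Compound 2, `CC(C)(C)c1ccc(S(=O)(=O)N[C@H]2CCN(Cc3cc4cc[nH]cc-4n3)C2=O)cc1`, gives 57% in this assay.

Compound 2 stands highest of the two numbers shown, but its only companion is compound 1, and the step of a number 8 percentage points higher from compound 1 to compound 2 (within the scatter) lies within the scatter, so the two cannot really be told apart. Compound 3, `CC(C)(C)c1ccc(S(=O)(=O)N[C@H]2CCN(CCNc3ccncc3)C2=O)cc1`, has not yet been measured. It differs from compound 2 in one place: a group of 8 heavy atoms (6 carbon, 2 nitrogen; one six-membered aromatic ring with 1 hetero atom) in place of a group of 9 heavy atoms (7 carbon, 2 nitrogen; one five-membered aromatic ring with 1 hetero atom, one six-membered aromatic ring with 1 hetero atom), on a saturated chain carbon bound to an amide-type nitrogen in a ring. Going by the values given here, the single measured step, a number 8 percentage points higher from compound 1 to compound 2 (within the scatter), concerns a different place, the group on the sulfonyl sulfur, and so says nothing directly about the change made in compound 3. No measured step bears on this change, and the part of the molecule that is altered has not been varied anywhere else among the compounds shown. The expectation therefore rests on the shared core alone, and the step of a number 12 percentage points lower from compound 2 to compound 3 (beyond the scatter) is expected to be small, with wide uncertainty in either direction. Compound 3 is estimated at 45%, within a range of 10% to 75% in this assay.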

Compound 3, a percentage reported as inhibition, at one concentration (the size of the read-out at that concentration, not a potency): 14%
Compound 3: middle estimate off by 31 percentage points, on the high side; measured number inside the range.
By their numbers in this assay, from the lowest: compound 3; then compounds 1 and 2 (each within the scatter of the next).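

This is the first change shown on a saturated chain carbon bound to an amide-type nitrogen in a ring. In this assay, replacing the group with one five-membered and one six-membered aromatic ring by ((pyridin-4-yl)amino)methyl gives a number 43 percentage points lower from compound 2 to compound 3 (beyond the scatter), whereas the earlier change on the sulfonyl sulfur, a number 8 percentage points higher from compound 1 to compound 2 (within the scatter), could not be told from noise, so the read-out clearly responds to what sits at this position, at least for this pair of groups. No measurement shown explains the drop, and which part of the exchange matters remains unknown.

The exchange removes the five-membered aromatic ring and brings in an amino link at once, and the compounds shown cannot separate these two changes; a pyridin-4-yl group without the amino link, or a simple amine in its place, would be needed to pull them apart. Going by these compounds, it also remains open whether ((pyridin-4-yl)amino)methyl would cost as much with 5-(1,2-oxazol-3-yl)thiophen-2-yl on the sulfonyl sulfur as it does with 4-(tert-butyl)phenyl.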